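This account rests on a few compounds, and the source may have more. Where it says the series, first, only, none or still open, it means among the compounds named here.

Measured compounds:
- compound 1, `O=C(O)c1ccccc1-c1ccc(CCc2ncc(C3CCCCC3)[nH]2)cc1`, 14.7 nM
- compound 2, `COc1cccc(Cc2cnc(CCc3ccc(-c4ccccc4C(=O)O)cc3)[nH]2)c1`, 79 nM
- compound 3, `COc1ccc(Cc2cnc(CCc3ccc(-c4ccccc4C(=O)O)cc3)[nH]2)cc1`, 513 nM

In an in vitro functional assay on cells for agonist activity at Bombesin receptor subtype-3 (Mus musculus), read by luminescence and calcium flux (on this read-out lower numbers stand for an effect already at smaller amounts and higher numbers for an effect only at larger amounts of compound), compound 3 stands at the highest number of the three. Its nearest neighbour is compound 2, with a 6.5-fold higher number from compound 2 to compound 3 (0.81 log units; beyond the scatter); compound 1 is furthest, with a 35-fold higher number from compound 1 to compound 3 (1.54 log units; beyond the scatter).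

Compound 4, `O=C(O)c1ccccc1-c1ccc(CCc2ncc(CCc3ccccc3)[nH]2)cc1`, is not yet measured. It differs from compound 3 by benzyl in place of 4-methoxyphenyl on a saturated chain carbon bound to an aromatic carbon.

Among the compounds with values here, two measured steps bear on this. The step of a 6.5-fold higher number from compound 2 to compound 3 (0.81 log units; beyond the scatter) shows that the position of the methoxy group on this ring carries a modest, beyond-scatter difference, with the 4-methoxy arrangement at the higher number. The step of a 35-fold higher number from compound 1 to compound 3 (1.54 log units; beyond the scatter) shows that a substituent without an oxygen acceptor at this place gives by far the lowest number in the set. Removing the methoxy group altogether is not covered by any measured pair, so direction is uncertain; on this basis a modest fall in number is expected, not a large one. The step expected on this basis reads a 3.4-fold lower number from compound 3 to compound 4 (0.53 log units; beyond the scatter). Compound 4 is expected at 150 nM, with a range from 40 nM to 600 nM.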

Compound 4, half-maximal effective concentration: 174 nM
Estimate against measurement, compound 4: 1.2-fold (0.06 log units) below; the measured number falls inside the stated range.
By their numbers in this assay, from the lowest: compound 1; then compound 2; then compound 4; then compound 3.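

In this assay, phenethyl at this place lands between the two methoxybenzyl groups, with a 2.9-fold lower number from compound 3 to compound 4 (0.47 log units; beyond the scatter) and a 2.2-fold higher number from compound 2 to compound 4 (0.34 log units; beyond the scatter), so a ring without a methoxy group sits inside the range those two isomers span rather than outside it. Cyclohexyl stays clearly ahead of this oxygen-free aromatic group, with a 12-fold higher number from compound 1 to compound 4 (1.07 log units; beyond the scatter), which shows that losing the oxygen alone does not reach the low number of compound 1. No measurement shown gives a reason for either difference.

The change from either methoxybenzyl to phenethyl removes the methoxy group and lengthens the link to the ring in one step, so the compounds shown cannot separate the two. Unsubstituted benzyl would address that, while cyclohexylmethyl would test whether the low number of compound 1 survives a longer chain.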